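Replacing the 4-hydroxyphenyl group of compound 3

The source may report more compounds than this note shows. Statements on the series, on what has been measured and on what is new or still open speak of the compounds shown alone.

In a functional assay on NCI-H460 cells (Homo sapiens) for cytotoxicity, read by sulforhodamine B assay (a lower number here means a stronger inhibitor of growth, a higher number a weaker inhibitor of growth), compound 1 `CC1=CC[C@@H]([C@@](C)(O)CCCC(C)(C)NC(=S)NN)CC1` gives 12800 nM, compound 2 `CC1=CC[C@@H]([C@@](C)(O)CCCC(C)(C)NC(=S)N/N=C\c2ccccc2)CC1` gives 38400 nM and compound 3 `CC1=CC[C@@H]([C@@](C)(O)CCCC(C)(C)NC(=S)N/N=C\c2ccc(O)cc2)CC1` gives 1460 nM, the lowest of the three numbers. Compound 4 `CC1=CC[C@@H]([C@@](C)(O)CCCC(C)(C)NC(=S)N/N=C\c2ccccc2[N+](=O)[O-])CC1` has 2-nitrophenyl in place of 4-hydroxyphenyl on a carbon with a double bond to nitrogen. The most relevant evidence is a 26-fold lower number from compound 2 to compound 3 (1.42 log units; beyond the scatter), a large step that came with hydroxy in place of hydrogen on an aromatic carbon. The steps of a 3.0-fold higher number from compound 1 to compound 2 (0.48 log units; beyond the scatter) and an 8.8-fold lower number from compound 1 to compound 3 (0.94 log units; beyond the scatter) show that the aromatic group can move the number either way. Going by the values given here, no measured compound carries a nitro group, so a modest rise, not the full large step, is expected. The expected step is a 6.8-fold higher number from compound 3 to compound 4 (0.84 log units; beyond the scatter). For compound 4 the estimated value is 10000 nM, with an expected range of 2500 nM to 35000 nM.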

Compound 4, concentration for 50% growth inhibition: 20600 nM
Compound 4: the middle estimate sits 2.1-fold (0.31 log units) below what was measured, and the stated range covers the measured number.
By their numbers in this assay, from the lowest: compound 3; then compounds 1, 4 and 2 (each within the scatter of the next, the first and the last beyond it).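

In this assay, 2-nitrophenyl in place of 4-hydroxyphenyl gave a 14-fold higher number from compound 3 to compound 4 (1.15 log units; beyond the scatter), so at this position the low number of compound 3 did not survive this exchange of aromatic groups. Nitro in place of hydrogen on the phenyl ring gave a 1.9-fold lower number from compound 2 to compound 4 (0.27 log units; within the scatter), so among the three aromatic groups shown, only 4-hydroxyphenyl stands apart. Nothing measured here explains this difference. As far as these compounds go, it remains open whether a methoxy group or an amine in place of the hydroxy group of compound 3 would keep its low number, and whether the outcome for nitro depends on its place on the ring.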